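The source may report more compounds than this note shows. Statements on the series, on what has been measured and on what is new or still open speak of the compounds shown alone.

For the measured compounds named here, compound 2 `CCCN(CCC)S(=O)(=O)NC(=O)Nc1c(C(C)C)cccc1C(C)C` is the lower of the two numbers so far in an assay on liver for inhibition of sterol O-acyltransferase 1 (Rattus norvegicus), using microsomes (on this read-out lower numbers stand for stronger inhibition and higher numbers for weaker inhibition), where compound 2 gives 1100 nM. Compound 1 `CCN(CC)S(=O)(=O)NC(=O)Nc1c(C(C)C)cccc1C(C)C` gives 2500 nM in this assay. Going by the values given here, the single change between them, a 2.3-fold lower number from compound 1 to compound 2 (0.36 log units; beyond the scatter), enlarged the amino group on the sulfonyl sulfur. Compound 3 `CC(C)c1cccc(C(C)C)c1NC(=O)NS(=O)(=O)N(C(C)C)C(C)(C)C` alters that same group once more: isopropyl(tert-butyl)amino in place of dipropylamino on a sulfonyl sulfur. Among the compounds with values here, only that one modest step bears on this change, so a small step or none beyond the scatter is expected. Compound 3 is therefore estimated at 800 nM, with a range from 300 nM to 2500 nM. This corresponds to an expected step of a 1.4-fold lower number from compound 2 to compound 3 (0.14 log units; within the scatter).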

Compound 3, half-maximal inhibitory concentration: 140 nM
For compound 3 the middle estimate is 5.7-fold (0.76 log units) above the measured one, outside the stated range (below it).
By their numbers in this assay, from the lowest: compound 3; then compound 2; then compound 1.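

Replacing the straight chains with isopropyl(tert-butyl)amino shows that this group on the sulfonyl sulfur can shift the result far more than the first change did in this assay: the new group gives a 7.9-fold lower number from compound 2 to compound 3 (0.90 log units; beyond the scatter), and an 18-fold lower number from compound 1 to compound 3 (1.25 log units; beyond the scatter). Among these three compounds, the lowest number belongs to the only one with isopropyl and tert-butyl on that nitrogen. Nothing available explains this gain.

On these data alone, whether isopropyl or tert-butyl matters more remains open, since both enter together. It is also unknown how diisopropylamino or dibutylamino would compare.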